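From 4-fluorophenyl to 4-chlorophenyl

The compounds below may be only part of what the source reports. "The series", "measured", "known", "first", "only" and "open" are said of these compounds alone.

In a functional assay on SMMC-7721 cells (Homo sapiens) for inhibition, read by CCK-8 assay, with a stated time of 72 h, tested at 8 uM (on this read-out higher numbers stand for more inhibition of growth at the one concentration tested and lower numbers for less inhibition of growth), compound 1 (`CCc1ccc(SCc2ccc(C(=O)Nc3ccccc3N)cc2)cc1`) gives 82.9%. Compound 2 (`Nc1ccccc1NC(=O)c1ccc(CSc2ccc(F)cc2)cc1`) gives 81.9%, which places it level with compound 1 within the scatter.

Compound 3 (`Nc1ccccc1NC(=O)c1ccc(CSc2ccc(Cl)cc2)cc1`) carries chloro in place of fluoro on an aromatic carbon, para to a large group: chloro in place of fluoro on an aromatic carbon. This turns the 4-fluorophenyl into a 4-chlorophenyl, and the rest of the structure stays the same.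

For the measured compounds named here, only one measured step bears on this change: a number 1 percentage points lower from compound 1 to compound 2 (within the scatter), with fluoro in place of ethyl on that same aromatic carbon. Going by the values given here, that step stays within the scatter, and it is the only evidence available, so no step beyond the scatter is expected in this assay. The expected size is a number 0.1 percentage points higher from compound 2 to compound 3 (within the scatter). Compound 3 is estimated at 82%, with an expected range of 72% to 91%.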

Compound 3, percent growth inhibition at one concentration: 16.5%
Compound 3: the middle estimate sits 65.5 percentage points above what was measured, outside the stated range (below it).
By their numbers in this assay, from the lowest: compound 3; then compounds 2 and 1 (each within the scatter of the next).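

At the aromatic carbon para to a large group, ethyl and fluoro read level within the scatter, so the position looked tolerant, but in this assay chloro gives a number 65.4 percentage points lower from compound 2 to compound 3 (beyond the scatter) and also a number 66.4 percentage points lower from compound 1 to compound 3 (beyond the scatter) within the same series. The position is therefore sensitive to the group it carries: the exchange of one heavy atom for another, with no change in ring, hydrogen-bond donor or acceptor counts or net charge, separates compound 3 from both neighbours. Nothing available explains why chloro stands apart from fluoro and ethyl.

On these data alone, whether the loss is confined to chloro or extends to bromo, methyl or methoxy at this position remains open. An amine or a carboxylic acid there could equally read level with compound 1 and compound 2 or fall with compound 3.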